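This account rests on a few compounds, and the source may have more. Where it says the series, first, only, none or still open, it means among the compounds named here.

Notes on the series in a functional assay on DU-145 cells (Homo sapiens) for cytotoxicity, read by sulforhodamine B assay, with a stated time of 48 h; on this read-out higher numbers stand for weaker inhibition of growth and lower numbers for stronger inhibition of growth. Compound 1 `CCN1CCN(c2nc(Nc3ccc(C#N)c(C(F)(F)F)c3)nc(Oc3ccnc4ccccc34)n2)CC1` gives in this assay only a limit of the assay, > 100000 nM. Compound 2 `N#Cc1ccc(Nc2nc(Oc3ccnc4ccccc34)nc(N3CCN(c4ccccn4)CC3)n2)cc1C(F)(F)F` likewise gives in this assay only a limit, > 100000 nM. Going by the values given here, the single step between them, a step that the two limits leave unreadable from compound 1 to compound 2, cannot be read in size, because of the limit of > 100000 nM in this assay, at which 2 of the 2 values shown sit. Compound 2 thus stands at the limit and nowhere else on the numbers shown. Compound 3 `COc1ccc(N2CCN(c3nc(Nc4ccc(C#N)c(C(F)(F)F)c4)nc(Oc4ccnc5ccccc45)n3)CC2)cc1` is not yet measured; it differs from compound 2 by 4-methoxyphenyl in place of pyridin-2-yl on an amine nitrogen in a ring. Only the unreadable step bears on this change, so it yields no direction and no size, and both measured values sit at the limit. Compound 3 is therefore expected to stand near that limit as well, with an estimate of 100000 nM and a range from 30000 nM to 300000 nM. The expected step, a number no higher from compound 2 to compound 3 (the limit leaves the size open), is counted as no change beyond the scatter, and a limit rather than a number is the expected outcome.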

Compound 3, concentration for total growth inhibition: > 100000 nM
Compound 3 was reported as a limit (the forecaster's own chance of this, stated with the estimate: 80%); the middle value sits exactly at the limit.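

No step can be read among compound 1, compound 2 and compound 3, since each result is a limit and not a number: (the limit of > 100000 nM in this assay, at which 3 of the 3 values shown sit). On these data alone, whether ethyl, pyridin-2-yl and 4-methoxyphenyl on the ring amine nitrogen differ in growth inhibition remains open.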